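The source may hold more compounds than are shown below. What is called first, only, known or untested is meant among the compounds shown, and "the series" means these compounds.

Compound 1 `C=C1[C@@H](OC(C)=O)C[C@@H]2[C@](C)(CO[Si](C)(C)C(C)(C)C)[C@H](OC(C)=O)CC[C@@]2(C)[C@@H]1C[C@@H](Nc1ccc(OC)c(OC)c1)C1=CCOC1=O`: 4310 nM
Compound 2 `C=C1CC[C@@H]2[C@](C)(CO[Si](C)(C)C(C)(C)C)[C@H](OC(C)=O)CC[C@@]2(C)[C@@H]1C/C=C1/C(=O)OC[C@H]1OC(C)=O`: 4840 nM
Compound 3 `C=C1[C@@H](OC(C)=O)C[C@@H]2[C@](C)(COC=O)[C@H](OC(C)=O)CC[C@@]2(C)[C@@H]1C/C=C1/C(=O)OC[C@H]1OC(C)=O`: 12900 nM

In a functional assay on MCF7 cells (Homo sapiens) for cytotoxicity, read by sulforhodamine B assay (on this read-out higher numbers stand for weaker inhibition and lower numbers for stronger inhibition), compound 1 gives 4310 nM. This sits within the usual scatter of compound 2, while compound 3 gives a clearly higher number. Compound 4 `C=C1[C@@H](OC(C)=O)C[C@@H]2[C@](C)(CO[Si](C)(C)C(C)(C)C)[C@H](OC(C)=O)CC[C@@]2(C)[C@@H]1C[C@@H](Nc1cccc(F)c1)C1=CCOC1=O` carries 3-fluorophenyl in place of 3,4-dimethoxyphenyl on an amine nitrogen. Among the compounds with values here, no two measured compounds differ in only one place, so nothing here shows directly what this swap does. The safest expectation in this assay is therefore no change beyond the scatter, in either direction. The expected change is small: a 1.1-fold lower number from compound 1 to compound 4 (0.05 log units; within the scatter). For compound 4 the estimated value is 3800 nM, with an expected range of 1500 nM to 9500 nM.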

Compound 4, half-maximal inhibitory concentration: 3820 nM
The estimate for compound 4 lay 1.0-fold (0.00 log units) below the measured number; measured number inside the range.
By their numbers in this assay, from the lowest: compounds 4, 1 and 2 (each within the scatter of the next); then compound 3.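

Swapping 3,4-dimethoxyphenyl for 3-fluorophenyl on the amine nitrogen gives the first single-place comparison in this assay, with a 1.1-fold lower number from compound 1 to compound 4 (0.05 log units; within the scatter). At this position, then, these two aryl groups read alike, even though the group that enters has fewer heavy atoms and no hydrogen-bond acceptors. Nothing measured here explains this result.

The compounds shown leave open whether a ring is needed on this nitrogen at all. A pyridine ring, a phenyl ring bearing a carboxylic acid, or a simple butyl chain could still behave differently.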